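The compounds below may be only part of what the source reports. "The series", "measured", "known", "first", "only" and "open" are said of these compounds alone.

Three compounds share one core and differ only in the group on a saturated chain carbon bound to a nitrogen on an aromatic ring. Compound 1 `CC(C)CNc1ccc(NC(=O)c2cc(Cl)ccc2O)c(Cl)c1` carries isopropyl there, and in an ADME assay on A549 cells (Homo sapiens) for cytotoxicity, read by resazurin assay, with a stated time of 48 h (on this read-out higher numbers stand for lower toxicity in this test and lower numbers for higher toxicity in this test), compound 1 gives 60000 nM. Compound 2 `O=C(Nc1ccc(NCc2ccc(Br)cc2)cc1Cl)c1cc(Cl)ccc1O` carries 4-bromophenyl, and compound 2 gives 40900 nM. Compound 3 `O=C(Nc1ccc(NCc2ccc(C(F)(F)F)cc2)cc1Cl)c1cc(Cl)ccc1O` carries 4-(trifluoromethyl)phenyl, and compound 3 gives 62700 nM. The steps among them are small: a 1.5-fold lower number from compound 1 to compound 2 (0.17 log units; within the scatter), a 1.0-fold higher number from compound 1 to compound 3 (0.02 log units; within the scatter) and a 1.5-fold higher number from compound 2 to compound 3 (0.19 log units; within the scatter). Compound 3 has the highest of the three numbers, yet each of its steps to the others lies within the scatter, so the three stand level.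

Compound 4 `O=C(Nc1ccc(NCc2cccc(Br)n2)cc1Cl)c1cc(Cl)ccc1O` differs from compound 3 in one place: 6-bromopyridin-2-yl in place of 4-(trifluoromethyl)phenyl on a saturated chain carbon bound to a nitrogen on an aromatic ring. Going by the values given here, the steps that bear on this are the three swaps of the group on that carbon, and none of them moved the number beyond the scatter. The expected step from compound 3 to compound 4 is therefore a 1.1-fold lower number from compound 3 to compound 4 (0.06 log units; within the scatter), no larger than the scatter. Compound 4 is estimated to give 55000 nM in this assay, with a range from 30000 nM to 100000 nM.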

Compound 4, half-maximal cytotoxic concentration: 92300 nM
The estimate for compound 4 lay 1.7-fold (0.22 log units) below the measured number; the measured number falls inside the stated range.
By their numbers in this assay, from the lowest: compounds 2, 1, 3 and 4 (each within the scatter of the next, the first and the last beyond it).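

The swap on a saturated chain carbon bound to a nitrogen on an aromatic ring can now move the number beyond the scatter in this assay, since 6-bromopyridin-2-yl in place of 4-bromophenyl gives a 2.3-fold higher number from compound 2 to compound 4 (0.35 log units; beyond the scatter) as a modest step, the first here to leave the scatter. The other two swaps stay within it, with a 1.5-fold higher number from compound 3 to compound 4 (0.17 log units; within the scatter) and a 1.5-fold higher number from compound 1 to compound 4 (0.19 log units; within the scatter) as the steps, so 6-bromopyridin-2-yl stands level with 4-(trifluoromethyl)phenyl and isopropyl and apart only from 4-bromophenyl. Nothing shown here offers a reason for that one modest step.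

Going by these compounds, whether an amine or a carboxylic acid on that carbon would shift the number further remains open. So does whether a pyridine ring without its bromo would stand with compound 4 or with compound 2.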